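The source may hold more compounds than are shown below. What is called first, only, known or untested is meant among the compounds shown, and "the series" means these compounds.

Within the data shown here, in a functional assay on PC-3 cells (Homo sapiens) for cytotoxicity, read by MTT assay, with a stated time of 48 h (a higher number here means a weaker inhibitor, a lower number a stronger inhibitor), two compounds built on the same core have numbers so far. Compound 1 (`COc1cccc(OC)c1/C=C/[C@](C)(O)CC[C@@H]1[C@@]2(C)CCCC(C)(C)[C@@H]2CC[C@@]1(C)O`) gives 4000 nM, and compound 2 (`COc1cccc(/C=C/[C@](C)(O)CC[C@@H]2[C@@]3(C)CCCC(C)(C)[C@@H]3CC[C@@]2(C)O)c1OC`) gives 2900 nM. Among the measured compounds shown here, compound 2 therefore stands level with compound 1 on these numbers, since the only measured step, a 1.4-fold lower number from compound 1 to compound 2 (0.14 log units; within the scatter), does not clear the scatter. That step puts 2,3-dimethoxyphenyl in place of 2,6-dimethoxyphenyl.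

Compound 3 (`Cc1cccc(C)c1/C=C/[C@](C)(O)CC[C@@H]1[C@@]2(C)CCCC(C)(C)[C@@H]2CC[C@@]1(C)O`) makes a different kind of change: 2,6-dimethylphenyl in place of 2,3-dimethoxyphenyl on a double-bonded chain carbon bound to a double-bonded chain carbon. Here 2,6-dimethylphenyl replaces 2,3-dimethoxyphenyl on a double-bonded chain carbon bound to a double-bonded chain carbon. For the measured compounds named here, no measured pair yet shows what replacing the dimethoxyphenyl group with a dimethylphenyl group does, so the evidence is thin. Going by the values given here, the one guide is that the exchange of one dimethoxyphenyl group for another in compound 2 gave only a 1.4-fold lower number from compound 1 to compound 2 (0.14 log units; within the scatter).

The estimated change is a 1.2-fold higher number from compound 2 to compound 3 (0.08 log units; within the scatter), so no shift beyond the scatter is expected in this assay, in either direction. Compound 3 is expected at about 3500 nM, within an estimated range of 1300 nM to 9000 nM.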

Compound 3, half-maximal inhibitory concentration: 278 nM
Beside the measured number, compound 3's estimate is 13-fold (1.10 log units) above it; the whole stated range lies above it.
By their numbers in this assay, from the lowest: compound 3; then compounds 2 and 1 (each within the scatter of the next).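

In this assay, the group on a double-bonded chain carbon bound to a double-bonded chain carbon now proves able to change the result, which the two dimethoxyphenyl compounds alone did not show. Putting 2,6-dimethylphenyl in place of 2,3-dimethoxyphenyl gives a 10-fold lower number from compound 2 to compound 3 (1.02 log units; beyond the scatter) and putting it in place of 2,6-dimethoxyphenyl gives a 14-fold lower number from compound 1 to compound 3 (1.16 log units; beyond the scatter), so compound 3 has the lowest number of the three and the change holds against both dimethoxyphenyl groups. The second step is the more telling one, as the numbers in the two group names stay the same and the methoxy groups are exchanged for methyl groups, yet no measurement here explains the gain.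

These compounds cannot separate the effect of removing the oxygen atoms from the effect of adding the methyl groups, nor show whether the arrangement of the methyl groups in 2,6-dimethylphenyl matters. A plain phenyl, a 2,3-dimethylphenyl or a 2,6-dichlorophenyl group at the same place on the shared core would help to answer those questions.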